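Replacing the alkenyl group of compound 3

A few compounds are considered here, and "the series" means these few. Any claim that something is new, unique, unknown or untested is made for them only; others in the source may bear on it.

Values in a functional assay on MCF7 cells (Homo sapiens) for antiproliferative activity, read by MTT assay, with a stated time of 72 h; a higher number here means a weaker inhibitor, a lower number a stronger inhibitor:
- Compound 1 `CC/C=C/C(=O)Nc1cccc(Oc2nc(Nc3ccn(C)n3)nc3c2CSCC3)c1`: > 50000 nM (a limit)
- Compound 2 `CCC/C=C/C(=O)Nc1cccc(Oc2nc(Nc3ccn(C)n3)nc3c2CSCC3)c1`: 22600 nM
- Compound 3 `CC(C)=CC(=O)Nc1cccc(Oc2nc(Nc3ccn(C)n3)nc3c2CSCC3)c1`: > 50000 nM (a limit)

Compound 3 stands at > 50000 nM, which is a limit and not a number. Most of the series sits at the limit of > 50000 nM in this assay, at which 2 of the 3 values shown sit.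

Compound 4 `C=C(F)C(=O)Nc1cccc(Oc2nc(Nc3ccn(C)n3)nc3c2CSCC3)c1` carries 1-fluoroethenyl in place of 2-methylprop-1-en-1-yl on a carbonyl carbon.

Going by the values given here, the steps that bear on this change alter the group on the same carbonyl carbon. They run an at least 2.2-fold lower number from compound 1 to compound 2 (0.34 log units; beyond the scatter) and an at least 2.2-fold higher number from compound 2 to compound 3 (0.34 log units; beyond the scatter), while the third reads a step that the two limits leave unreadable from compound 1 to compound 3. Only compound 2 gives a number, 22600 nM. From these steps, a modest move toward a lower number is expected in this assay, although compound 4 may also end at a limit.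

The estimate means an expected at least 1.6-fold lower number from compound 3 to compound 4 (0.22 log units; that floor lies within the scatter). For compound 4 the expected value is 30000 nM, with an estimated range from 9000 nM to 50000 nM.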

Compound 4, half-maximal inhibitory concentration: > 50000 nM
Compound 4: a limit, no number; the forecaster's own chance of this, stated with the estimate: 45%; middle value at least 1.6-fold (0.22 log units) away from the limit.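

In this assay compound 4 gives > 50000 nM, which is a limit and not a number. With 1-fluoroethenyl in place of pent-1-en-1-yl on the carbonyl carbon, the result is an at least 2.2-fold higher number from compound 2 to compound 4 (0.34 log units; beyond the scatter), so a second group besides the 2-methylprop-1-en-1-yl of compound 3 now falls short of compound 2. The steps linking compound 4 with compound 1 and compound 3 cannot be read, and the pent-1-en-1-yl of compound 2 remains the only group here that gives a number: the limit of > 50000 nM in this assay, at which 3 of the 4 values shown sit.

The compounds shown do not tell how compound 1, compound 3 and compound 4 rank among themselves. They also leave open whether a longer chain than pent-1-en-1-yl, or an amine carried on that chain, would give a lower number than compound 2.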